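The source may report more compounds than this note shows. Statements on the series, on what has been measured and on what is new or still open speak of the compounds shown alone.

Measured compounds:
- compound 1, `CCCCCCCCCCCC(=O)OC[C@H](CSC[C@@H](N)C(=O)NCCO)OC(=O)CCCCCCCCCCC`, 24 nM
- compound 2, `CCCCCCCCCCCC(=O)OC[C@H](CSC[C@@H](N)C(=O)NCCCS(=O)(=O)O)OC(=O)CCCCCCCCCCC`, 5560 nM
- compound 3, `CCCCCCCCCCCC(=O)OC[C@H](CSC[C@@H](N)C(=O)NC(C)CCC(C)C)OC(=O)CCCCCCCCCCC`, 190 nM

All three share the same lipidated core and differ only in the group on the amide-type nitrogen. In an assay on HEK293 cells for agonist activity at Toll-like receptor 2 (Homo sapiens) (a higher number here means that more compound is needed for the effect, a lower number that less compound is needed), compound 1 gives 24 nM, compound 2 gives 5560 nM, and compound 3 gives 190 nM. Compound 3 thus stands second among the three: it sits a 7.9-fold higher number from compound 1 to compound 3 (0.90 log units; beyond the scatter) away from compound 1 on one side, while the sulfopropyl analogue lies far off on the other, as shown by a 29-fold lower number from compound 2 to compound 3 (1.47 log units; beyond the scatter).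

Compound 4, `CCCCCCCCCCCC(=O)OC[C@H](CSC[C@@H](N)C(=O)NCCN)OC(=O)CCCCCCCCCCC`, has not yet been measured. Its change from compound 3 is 2-aminoethyl in place of 1,4-dimethylpentyl on an amide-type nitrogen. For the measured compounds named here, two measured steps bear on this. The step of a 7.9-fold higher number from compound 1 to compound 3 (0.90 log units; beyond the scatter) shows that exchanging a short hydroxy-bearing chain for the branched alkyl group cost potency; the step of a 29-fold lower number from compound 2 to compound 3 (1.47 log units; beyond the scatter) shows that a short chain carrying a sulfo group did far worse than the branched alkyl. The aminoethyl group in compound 4 is short like the chains of compound 1 and compound 2 and, like them, carries a hydrogen-bond donor and acceptor, so the outcome could fall on either side. Because the step of a 7.9-fold higher number from compound 1 to compound 3 (0.90 log units; beyond the scatter) was only modest, the expected step for compound 4 is a 4.8-fold lower number from compound 3 to compound 4 (0.68 log units; beyond the scatter), toward a lower number. Compound 4 is therefore estimated at 40 nM, with a range from 8 nM to 250 nM.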

Compound 4, half-maximal effective concentration: 5240 nM
Compound 4: the middle estimate sits 130-fold (2.12 log units) below what was measured; measured number outside the range, above it.
By their numbers in this assay, from the lowest: compound 1; then compound 3; then compounds 4 and 2 (each within the scatter of the next).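

In this assay, amino in place of hydroxy on the saturated chain carbon gives a 220-fold higher number from compound 1 to compound 4 (2.34 log units; beyond the scatter), so at this position a short chain does not by itself secure a low number, and the group it carries can decide the outcome. The 2-aminoethyl group also falls behind the 1,4-dimethylpentyl group, with a 28-fold higher number from compound 3 to compound 4 (1.44 log units; beyond the scatter), and amino in place of sulfomethyl gives a 1.1-fold lower number from compound 2 to compound 4 (0.03 log units; within the scatter), which places the amino-bearing and sulfo-bearing chains level, both on the far side of the branched alkyl group from the hydroxy-bearing chain. Nothing available bears on why the amino and hydroxy chains lie so far apart.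

The compounds shown leave open whether the low number of compound 1 depends on the free hydroxy itself or would survive with a methoxy group or a longer hydroxy-bearing chain such as 3-hydroxypropyl. They also leave open whether a carboxylic acid on the short chain, or the amine of the 2-aminoethyl group capped as an acetamide, would stand with compound 4 or with compound 1.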